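A few compounds are considered here, and "the series" means these few. Any claim that something is new, unique, unknown or untested is made for them only; others in the source may bear on it.

In a functional assay on HepG2 cells (Homo sapiens) for cytotoxicity, read by MTT assay, with a stated time of 24 h (on this read-out higher numbers stand for weaker inhibition and lower numbers for stronger inhibition), compound 1 `O=C1/C(=C/c2ccccc2F)CN(S(=O)(=O)c2ccc(F)cc2)C/C1=C\c1ccccc1F` gives 7220 nM, compound 2 `CC(=O)Nc1ccc(S(=O)(=O)N2C/C(=C\c3ccccc3F)C(=O)/C(=C/c3ccccc3F)C2)cc1` gives 5840 nM and compound 3 `COc1cc(/C=C2\CN(S(=O)(=O)c3ccc(F)cc3)C/C(=C\c3ccc(C#N)cc3)C2=O)cc(OC)c1OC` gives 4950 nM. Compound 2 stands among these three numbers with its gaps to compound 1 and to compound 3 both within the scatter, so no ranking can be read from them.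

The next compound is compound 4 `CC(=O)Nc1ccc(S(=O)(=O)N2C/C(=C\c3cccc([N+](=O)[O-])c3)C(=O)/C(=C/c3ccccc3F)C2)cc1`, which keeps the acetamido group of compound 2. The change is 3-nitrophenyl in place of 2-fluorophenyl on a double-bonded chain carbon bound to a double-bonded ring carbon.

Among the measured compounds shown here, only one measured step between compounds differing in one place is available: a 1.2-fold lower number from compound 1 to compound 2 (0.09 log units; within the scatter). It places acetamido in place of fluoro on an aromatic carbon, so it concerns a different site and does not test this exchange directly. Compound 3, which carries other aromatic groups on its double-bonded chain carbons, gives 4950 nM, a number within the scatter of compound 2. No measured change has yet moved this assay beyond the scatter, so no step beyond it is expected here, and no direction can be favoured.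

The expected outcome is a 1.2-fold lower number from compound 2 to compound 4 (0.07 log units; within the scatter). For compound 4 the estimated value is 5000 nM, with an expected range of 2400 nM to 10500 nM.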

Compound 4, half-maximal inhibitory concentration: 8800 nM
Beside the measured number, compound 4's estimate is 1.8-fold (0.25 log units) below it; low and high end bracket the measured number.
By their numbers in this assay, from the lowest: compounds 3, 2, 1 and 4 (each within the scatter of the next).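

In this assay the exchange of 2-fluorophenyl for 3-nitrophenyl on a double-bonded chain carbon bound to a double-bonded ring carbon gives a 1.5-fold higher number from compound 2 to compound 4 (0.18 log units; within the scatter) and so shows no readable effect of this exchange, with the acetamido group held constant. Among the compounds shown here, this is the first direct test at this position, and together with a 1.2-fold lower number from compound 1 to compound 2 (0.09 log units; within the scatter) at a different site it means that single changes in two places have now been read, neither moving the number beyond the scatter. No measurement at hand offers an explanation for this result.

Going by these compounds, it remains open whether any group at this position can move the number beyond the scatter in this assay, for example a phenyl ring carrying a dimethylamino group or a carboxylic acid, or a longer alkyl chain in place of the aromatic ring. Compound 4 also keeps its other 2-fluorophenyl group, so the compounds shown leave open whether replacing that group as well would give a step that can be read.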